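A few compounds are considered here, and "the series" means these few. Any claim that something is new, unique, unknown or untested is made for them only; others in the source may bear on it.

Three hydrazones built on one shared core have been tested in a functional assay on PC-3 cells (Homo sapiens) for inhibition; a higher number here means a weaker inhibitor, a lower number a stronger inhibitor. Compound 3 `Cc1c(C(=O)N/N=C\c2ccc(O)cc2)oc2cccc(O)c12` gives 21700 nM in this assay, the highest of the two plain numbers reported. Compound 1 `Cc1c(C(=O)N/N=C\c2ccccc2O)oc2cccc(O)c12` gives 8350 nM in this assay, and the step of a 2.6-fold higher number from compound 1 to compound 3 (0.41 log units; beyond the scatter) came with 4-hydroxyphenyl in place of 2-hydroxyphenyl. Compound 2 `Cc1c(C(=O)N/N=C\c2cccc(F)c2)oc2cccc(O)c12` reaches only a limit of this assay, >= 40000 nM. The step of an at least 4.7-fold higher number from compound 1 to compound 2 (0.68 log units; beyond the scatter) came with 3-fluorophenyl in place of 2-hydroxyphenyl. Compound 4 `Cc1c(C(=O)N/N=C\c2cccc(O)c2O)oc2cccc(O)c12` differs from compound 3 by 2,3-dihydroxyphenyl in place of 4-hydroxyphenyl on a carbon with a double bond to nitrogen. Since the entering 2,3-dihydroxyphenyl resembles the 2-hydroxyphenyl of compound 1, which gives 8350 nM in this assay, the expected step is a 2.4-fold lower number from compound 3 to compound 4 (0.38 log units; beyond the scatter). Compound 4 is therefore estimated at 9000 nM in this assay, within 3000 nM to 30000 nM.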

Compound 4, half-maximal inhibitory concentration: 12200 nM
The estimate for compound 4 lay 1.4-fold (0.13 log units) below the measured number; low and high end bracket the measured number.
By their numbers in this assay, from the lowest: compounds 1, 4 and 3 (each within the scatter of the next, the first and the last beyond it). At a limit, above all of these: compound 2.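

In this assay, the added hydroxy of the 2,3-dihydroxyphenyl group shifts the reading only within the scatter, with a 1.5-fold higher number from compound 1 to compound 4 (0.16 log units; within the scatter), and the exchange for 4-hydroxyphenyl also stays within it, with a 1.8-fold lower number from compound 3 to compound 4 (0.25 log units; within the scatter). Only the exchange for 3-fluorophenyl clears the scatter, with an at least 3.2-fold lower number from compound 2 to compound 4 (0.51 log units; beyond the scatter). That step is a floor, since compound 2 stands at a limit: the limit of >= 40000 nM in this assay, at which 1 of the 4 values shown sits.

On these data alone, what a methoxy group or an amine would give in place of these hydroxy groups stays open. So does the full size of the step from compound 2.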